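The compounds below may be only part of what the source reports. "The series", "measured", "known", "first", "only" and "open" are said of these compounds alone.

Measured so far in an assay on HEK293 cells for negative allosteric modulation of metabotropic glutamate receptor 5 (Homo sapiens), read by FLIPR; on this read-out higher numbers stand for weaker inhibition and lower numbers for stronger inhibition:
compound 1 `O=C(C1CCC(F)(F)CC1)N1CC(c2nc(-c3cccc(F)c3)no2)C1` gives > 10000 nM, a limit of the assay rather than a number.
compound 2 `CC1CCCCC1C(=O)N1CC(c2nc(-c3cccc(F)c3)no2)C1` gives > 10000 nM, again a limit rather than a number.

Compound 2 thus stands only at a limit in this assay. The step that the two limits leave unreadable from compound 1 to compound 2 cannot be read because both values sit at the limit of > 10000 nM in this assay, at which 2 of the 2 values shown sit. Compound 3 `O=C(c1ccc(F)c(F)c1)N1CC(c2nc(-c3cccc(F)c3)no2)C1` differs from compound 2 by 3,4-difluorophenyl in place of 2-methylcyclohexyl on a carbonyl carbon. No readable measured step bears on this change, so nothing points to a shift beyond the scatter. The step that the limit leaves unreadable from compound 2 to compound 3 is therefore expected to be small. Compound 3 is estimated at 15000 nM, in a range from 3000 nM to 60000 nM, most likely again reported only as a limit.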

Compound 3, half-maximal inhibitory concentration: > 10000 nM
Compound 3 was reported as a limit (the forecaster's own chance of this, stated with the estimate: 75%); the middle value lies beyond the limit too.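

Within the data shown here, no step among compound 1, compound 2 and compound 3 can be read, because all three values are limits: the limit of > 10000 nM in this assay, at which 3 of the 3 values shown sit. Which group on the carbonyl carbon would give a measurable inhibition in this assay stays open.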